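Trifluoromethoxy for trifluoromethyl: a stability estimate

The source may report more compounds than this note shows. Statements on the series, on what has been measured and on what is new or still open speak of the compounds shown alone.

Measured in an ADME assay on microsomes from liver (Mus musculus) for metabolic stability, with a stated time of 30 min, tested at 1 uM; on this read-out lower numbers stand for a less stable compound and higher numbers for a more stable compound:
Compound 1 `N#C/N=C(\NCc1ccc(S(=O)(=O)c2cccc(C(F)(F)F)c2)cc1)Nc1ccncc1` gives 74%
Compound 2 `N#C/N=C(\NCc1ccc(S(=O)(=O)c2cccc3cccnc23)cc1)Nc1ccncc1` gives 11%

Of these two, compound 1 stands highest, at 74% in this assay here. Compound 3 `N#C/N=C(\NCc1ccc(S(=O)(=O)c2cccc(OC(F)(F)F)c2)cc1)Nc1ccncc1` carries trifluoromethoxy in place of trifluoromethyl on an aromatic carbon. Among the compounds with values here, the only measured step, a number 63 percentage points lower from compound 1 to compound 2 (beyond the scatter), put quinolin-8-yl in place of 3-(trifluoromethyl)phenyl, so it bears only loosely on this smaller change. A small downward step, or none beyond the scatter, is therefore expected in this assay here. The estimated step is a number 6 percentage points lower from compound 1 to compound 3 (within the scatter) as expected. For compound 3 the expected value is 68%, with an estimated range of 50% to 85% overall.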

Compound 3, percent of the compound remaining: 55%
Compound 3: middle estimate off by 13 percentage points, on the high side; measured number inside the range.
By their numbers in this assay, from the lowest: compound 2; then compound 3; then compound 1.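

In this assay, this aromatic carbon proves sensitive even to a small exchange: trifluoromethoxy in place of trifluoromethyl gives a number 19 percentage points lower from compound 1 to compound 3 (beyond the scatter). Even so, the 3-(trifluoromethoxy)phenyl group retains much of the advantage over quinolin-8-yl on the sulfonyl sulfur, with a number 44 percentage points higher from compound 2 to compound 3 (beyond the scatter). No available evidence explains either step.

The compounds shown leave open how a methyl group or a chlorine atom on this aromatic carbon would read in this assay. They also leave open whether the step from trifluoromethyl to trifluoromethoxy would be the same on another core.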